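Ester in place of ketone on a stilbene-like scaffold

The source may report more compounds than this note shows. Statements on the series, on what has been measured and on what is new or still open speak of the compounds shown alone.

The shared core of compound 1 `COc1cc(OC)cc(C(=CC(C)=O)c2ccc(OC)c(OC)c2)c1` carries an enone side chain between its two aryl groups. In a functional assay on HCT-116 cells (Homo sapiens) for cytotoxicity, read by scintillation counting and thymidine incorporation, with a stated time of 72 h (a higher number here means a weaker inhibitor, a lower number a stronger inhibitor), compound 1 is reported only as a limit, > 10000 nM, and so its standing is a limit rather than a number; this is the one case of the limit of > 10000 nM in this assay, at which 1 of the 3 values shown sits, among the three values shown. Two nitrile analogues give numbers: compound 2 `COc1ccc(C(=CC#N)c2ccc(OC)c(OC)c2)cc1OC` reaches 140 nM in this assay, and compound 3 `COc1cc(OC)cc(/C(=C\C#N)c2ccc(OC)c(OC)c2)c1` reaches 11 nM in the same assay. For the measured compounds named here, no step between measured compounds differing in one place is available, so nothing connects the ketone of compound 1 to the nitriles by a single change.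

Compound 4 `COC(=O)C=C(c1cc(OC)cc(OC)c1)c1ccc(OC)c(OC)c1` differs from compound 1 by methoxy in place of methyl on a carbonyl carbon, that is, acetyl becoming methoxycarbonyl. Going by the values given here, with no measured pair to lean on, the step of a number no higher from compound 1 to compound 4 (the limit leaves the size open) is expected to stay within the scatter, in no firm direction. Compound 4 is therefore estimated at 10000 nM, between 2000 nM and 40000 nM, with a real chance that only a limit is reported again.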

Compound 4, half-maximal inhibitory concentration: > 10000 nM
Compound 4 was reported as a limit; the forecaster's own chance of this, stated with the estimate: 60%; the middle value sits exactly at the limit.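

In this assay compound 4 gives > 10000 nM, a limit and not a number. For the compounds shown here, compound 1 is also reported only as a limit, so no step between compound 1 and compound 4 can be read. The compounds shown leave open whether acetyl and methoxycarbonyl on this shared core differ at all in this assay.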